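This account rests on a few compounds, and the source may have more. Where it says the series, first, only, none or still open, it means among the compounds named here.

For the measured compounds named here, in a physicochemical assay for lipophilicity, at pH 7.4 (a lower number here means a more polar compound, a higher number a more lipophilic compound), compound 2 `Cc1nc(C)c(-c2nnc(-c3ccc(OC(C)C)c(Cl)c3)s2)s1` gives 7.76 as the higher of the two numbers so far, and compound 1 `CC(C)Oc1ccc(-c2nnc(-n3cncn3)s2)cc1Cl` gives 6.18 beyond the scatter below it. The move to compound 3 `Cc1[nH]ncc1-c1nnc(-c2ccc(OC(C)C)c(Cl)c2)s1` is 5-methyl-1H-pyrazol-4-yl in place of 2,4-dimethyl-1,3-thiazol-5-yl on an aromatic carbon on the shared core. Going by the values given here, the one measured step that bears on it is a number 1.58 log units higher from compound 1 to compound 2 (beyond the scatter) which is large and exchanges the group at this same place. A large fall in this assay is therefore expected, with a number 1.26 log units lower from compound 2 to compound 3 (beyond the scatter) as the estimated step. For compound 3 the estimated value of 6.5 carries an expected range from 5.9 to 7.1 on that scale.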

Compound 3, distribution coefficient: 5.45
Estimate against measurement, compound 3: 1.05 log units above; the whole stated range lies above it.
By their numbers in this assay, from the lowest: compound 3; then compound 1; then compound 2.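

In this assay the exchange gives a number 2.31 log units lower from compound 2 to compound 3 (beyond the scatter), although the leaving and entering groups are both five-membered aromatic rings with 2 hetero atoms. The same place also separates 5-methyl-1H-pyrazol-4-yl from 1H-1,2,4-triazol-1-yl, with a number 0.73 log units lower from compound 1 to compound 3 (beyond the scatter). No measurement available here accounts for these differences. The compounds shown do not separate the hydrogen-bond donor of the entering group from the other changes between the two rings. A 1,5-dimethyl-1H-pyrazol-4-yl group, with methyl on the ring nitrogen, would bear on that question.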